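The source may report more compounds than this note shows. Statements on the series, on what has been measured and on what is new or still open speak of the compounds shown alone.

Measured so far:
compound 1 `CC(C)SC1=NS(=O)(=O)c2cc(Cl)ccc2N1` gives 54.7%
compound 2 `CC(C)OC1=NS(=O)(=O)c2cc(Cl)ccc2N1` gives 85.8%

Both numbers come from a functional assay on the whole organism (uterus, Rattus norvegicus, strain Wistar) for inhibition, tested at 50 uM; a lower number here means a stronger effect, a higher number a weaker effect of the compound at the concentration tested. Among the measured compounds shown here, of the two, compound 2 stands highest; its only neighbour is compound 1, and the one measured step is a number 31.1 percentage points higher from compound 1 to compound 2 (beyond the scatter). Compound 3 `CC(C)NC1=NS(=O)(=O)c2cc(Cl)ccc2N1` is not yet measured; it differs from compound 2 by isopropylamino in place of isopropoxy on a carbon with a double bond to nitrogen. For the measured compounds named here, the single step available, isopropoxy in place of isopropylsulfanyl on a carbon with a double bond to nitrogen, was large, so exchanging the group on this carbon has already moved the read-out of this assay well beyond the scatter. Isopropylamino has no measured counterpart here, and there is no basis to say whether it behaves more like isopropoxy or like isopropylsulfanyl. A moderate downward step of a number 13.8 percentage points lower from compound 2 to compound 3 (beyond the scatter) is expected, with wide uncertainty. Compound 3 is therefore estimated at 72%, with a range from 45% to 100%.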

Compound 3, a percentage reported as activity, at one concentration (the size of the read-out at that concentration, not a potency): 95%
Compound 3: middle estimate off by 23 percentage points, on the low side, and the stated range covers the measured number.
By their numbers in this assay, from the lowest: compound 1; then compounds 2 and 3 (each within the scatter of the next).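

In this assay, exchanging isopropoxy for isopropylamino on the carbon with a double bond to nitrogen gives a number 9.2 percentage points higher from compound 2 to compound 3 (within the scatter), so the hydrogen-bond donor that isopropylamino carries and isopropoxy lacks does not separate these two compounds. Exchanging isopropylsulfanyl for isopropylamino at the same place gives a number 40.3 percentage points higher from compound 1 to compound 3 (beyond the scatter), which leaves compound 1, the isopropylsulfanyl member, as the only one of the three that stands apart in this assay. Nothing available explains why isopropylsulfanyl differs from the other two groups.

As far as these compounds go, it remains open whether this gap holds for sulfanyl groups in general, which an ethylsulfanyl or a cyclopentylsulfanyl group at this place could test. From the compounds shown here alone, the behaviour of a tertiary amine such as dimethylamino at this carbon, which carries no amine hydrogen, also remains open.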